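A few compounds are considered here, and "the series" means these few. Any claim that something is new, unique, unknown or untested is made for them only; others in the source may bear on it.

Of the compounds shown here, three that share one core have been measured in a functional assay on NCI-H460 cells (Homo sapiens) for cytotoxicity, read by MTT assay, with a stated time of 72 h; on this read-out lower numbers stand for stronger inhibition and higher numbers for weaker inhibition. Compound 1 `COc1ccc(/C=N/NC(=O)Nc2ccc(Oc3ccnc(-c4nncn4CCN(C)C)c3)c(F)c2)c(OC)c1OC` gives 1790 nM. Compound 2 `CN(C)CCn1cnnc1-c1cc(Oc2ccc(NC(=O)N/N=C/c3ccccc3)cc2F)ccn1` gives 1780 nM, and compound 3 `CN(C)CCn1cnnc1-c1cc(Oc2ccc(NC(=O)N/N=C/c3ccc(F)cc3)cc2F)ccn1` gives 1980 nM. Compound 3 carries the highest of the three numbers, but the gaps are small: a 1.1-fold higher number from compound 1 to compound 3 (0.04 log units; within the scatter) and a 1.1-fold higher number from compound 2 to compound 3 (0.05 log units; within the scatter), so all three stand level within the usual scatter of this assay.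

Compound 4 `CN(C)CCn1cnnc1-c1cc(Oc2ccc(NC(=O)N/N=C/c3ccc(Cl)cc3)cc2F)ccn1` has not yet been measured. It differs from compound 3 in one place: chloro in place of fluoro on an aromatic carbon. The new chloro sits on an aromatic carbon of a six-membered aromatic ring of carbon only, para to a large group.

Going by the values given here, two measured steps bear on this change. Exchanging the whole aryl group hardly moved the number, as shown by a 1.0-fold lower number from compound 1 to compound 2 (0.00 log units; within the scatter). Putting a fluoro onto that ring hardly moved it either, as shown by a 1.1-fold higher number from compound 2 to compound 3 (0.05 log units; within the scatter). Replacing fluoro with chloro on that aromatic carbon is a smaller alteration than either of those, so no step beyond the scatter is expected in this assay.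

Compound 4 is therefore expected to give about 1900 nM, with a range from 900 nM to 4000 nM. The expected step is a 1.0-fold lower number from compound 3 to compound 4 (0.02 log units; within the scatter).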

Compound 4, half-maximal inhibitory concentration: 320 nM
The estimate for compound 4 lay 5.9-fold (0.77 log units) above the measured number, and the stated range ends above it.
By their numbers in this assay, from the lowest: compound 4; then compounds 2, 1 and 3 (each within the scatter of the next).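

In this assay, going by these compounds alone, this aromatic carbon is not indifferent to what it carries: exchanging one halogen for another gives a 6.2-fold lower number from compound 3 to compound 4 (0.79 log units; beyond the scatter) even though only a single atom changes, whereas hydrogen and fluoro at the same carbon stand level within the scatter. The chloro compound also separates from the unsubstituted phenyl, with a 5.6-fold lower number from compound 2 to compound 4 (0.75 log units; beyond the scatter) as the step, and from the 2,3,4-trimethoxyphenyl group, with a 5.6-fold lower number from compound 1 to compound 4 (0.75 log units; beyond the scatter) as the step, so the flat picture from compound 1, compound 2 and compound 3 holds for those three aryl groups only and does not extend to 4-chlorophenyl. Nothing measured here accounts for the difference between chloro and fluoro on this ring.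

The compounds shown leave open whether the lower number belongs to chloro alone or would also appear with bromo, methyl, trifluoromethyl or a single methoxy group on the same carbon. They also leave open whether the same exchange of fluoro for chloro would give a step of similar size on a different core.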